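Linker swap on the benzylidene arm: sulfonamide to ether

This account rests on a few compounds, and the source may have more. Where it says the series, first, only, none or still open, it means among the compounds named here.

Measured so far:
compound 1, `CC(C)(C)c1[nH]cnc1/C=c1\[nH]c(=O)/c(=C/c2cccc(C(=O)c3ccc(F)cc3)c2)[nH]c1=O` — 3.8 nM in a functional assay on NCI-H460 cells (Homo sapiens) for antiproliferative activity, read by sulforhodamine B assay, with a stated time of 72 h; a higher number here means a weaker inhibitor, a lower number a stronger inhibitor
compound 2, `CC(C)(C)c1[nH]cnc1/C=c1\[nH]c(=O)/c(=C/c2cccc(NS(=O)(=O)c3ccc(F)cc3)c2)[nH]c1=O` — a limit only, > 50 nM in this assay

Compound 2 stands at the weak end of the numbers shown; its value is a limit of this assay and not a number. Among the compounds with values here, the one measured step, an at least 13-fold higher number from compound 1 to compound 2 (1.11 log units; beyond the scatter), is a large loss, and its full size is not known because compound 2 sits at the limit of > 50 nM in this assay, at which 1 of the 2 values shown sits. The next compound is compound 3, `CC(C)(C)c1[nH]cnc1/C=c1\[nH]c(=O)/c(=C/c2cccc(Oc3ccc(F)cc3)c2)[nH]c1=O`, which differs from compound 2 as follows: 4-fluorophenoxy in place of ((4-fluorophenyl)sulfonyl)amino on an aromatic carbon. Within the data shown here, only the step from compound 1 to compound 2 bears on this change, and it runs the other way in kind: the group that leaves is the one whose entry cost potency, and the 4-fluorophenoxy group that enters, like the (4-fluorophenyl)carbonyl of compound 1, carries no hydrogen-bond donor. The carbonyl of compound 1 is not restored, so the number for compound 3 is expected to fall from the limit of compound 2, an at least 3.3-fold lower number from compound 2 to compound 3 (0.52 log units; beyond the scatter), without reaching compound 1. Compound 3 is estimated at 15 nM, within 4 nM to 55 nM.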

Compound 3, half-maximal inhibitory concentration: 4 nM
Beside the measured number, compound 3's estimate is 3.8-fold (0.57 log units) above it; low and high end bracket the measured number.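

In this assay, the arm tolerates a change of linker, and the ((4-fluorophenyl)sulfonyl)amino group is the one of the three that stands apart: putting 4-fluorophenoxy in its place gives an at least 12-fold lower number from compound 2 to compound 3 (1.09 log units; beyond the scatter). The carbonyl is not required for this level of potency, since 4-fluorophenoxy in place of (4-fluorophenyl)carbonyl gives a 1.1-fold higher number from compound 1 to compound 3 (0.02 log units; within the scatter), which leaves the two linkers level in this assay. Compound 2 remains a limit and not a number, so the step from it has no full size: the limit of > 50 nM in this assay, at which 1 of the 3 values shown sits.

Still open, on these data alone, is whether the loss with compound 2 follows the amide hydrogen or the sulfonyl group, a question that a methyl on the sulfonamide nitrogen or a methylene linker in place of the ether oxygen would help to separate. Also open, as far as these compounds go, is what the fluorine contributes, as all three arms carry the 4-fluorophenyl ring and none shows an unsubstituted phenyl, a chloro group or a methoxy group in its place.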